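Chloro Added to Compound 1: An Expected Small Step

The source may report more compounds than this note shows. Statements on the series, on what has been measured and on what is new or still open speak of the compounds shown alone.

Compound 1 `O=c1c(Cc2coc3cccc(OCC4CCCCC4)c3c2=O)coc2ccccc12` is the only compound with a number in a functional assay on NUGC-3 cells (Homo sapiens) for antiproliferative activity, read by XTT assay; a lower number here means a stronger inhibitor, a higher number a weaker inhibitor: there compound 1 gives 3530 nM, and with only one number shown, that is where it stands. Compound 2 `O=c1c(/C=C/c2coc3ccccc3c2=O)coc2ccccc12` gives in this assay only a limit of > 10000 nM, not a number; it sits at the limit of > 10000 nM in this assay, at which 1 of the 2 values shown sits. Compound 3 `O=c1c(Cc2coc3cccc(OCC4CCCCC4)c3c2=O)coc2cc(Cl)ccc12` differs from compound 1 in a single place: chloro in place of hydrogen on an aromatic carbon of a six-membered aromatic ring of carbon only, part of a fused system of two rings, meta to a fused ring and para to a fused ring. Going by the values given here, no pair of measured compounds separated by one change is available, so the size of such a step in this assay has no earlier anchor. The author expects the change from compound 1 to compound 3 to be modest, most likely within the usual scatter and in either direction, and the estimated step is a 1.3-fold lower number from compound 1 to compound 3 (0.10 log units; within the scatter). Compound 3 is therefore estimated at 2800 nM, with an expected range from 900 nM to 8000 nM.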

Compound 3, half-maximal inhibitory concentration: > 10000 nM
Compound 3: no number, only a limit; the forecaster's own chance of this, stated with the estimate: 12%; middle value at least 3.5-fold (0.55 log units) away from the limit.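

In this assay, chloro in place of hydrogen on an aromatic carbon, meta to a fused ring and para to a fused ring, proves not to be a neutral change, giving an at least 2.8-fold higher number from compound 1 to compound 3 (0.45 log units; beyond the scatter). On these data alone, compound 3 gives > 10000 nM, which is a limit of the assay and not a number, so the step can be read only as a minimum and its true size remains unknown. This is the first step between measured compounds in this assay, and it shows that a single chlorine atom at this carbon of compound 1 is enough to take the activity out of the measurable range, leaving most of the values shown as limits: the limit of > 10000 nM in this assay, at which 2 of the 3 values shown sit.

What the compounds shown leave open is whether this loss belongs to chloro itself or to any replacement of hydrogen at this carbon, a question that a fluoro or a methoxy group in the same place would help to answer. They also leave open whether chloro on another aromatic carbon of the same ring would have the same effect, and what lies behind the loss.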